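The source may hold more compounds than are shown below. What is called first, only, known or untested is meant among the compounds shown, and "the series" means these compounds.

In a functional assay on cells (Cancer cell lines, Homo sapiens) for cytotoxicity, with a stated time of 48 h (a lower number here means a stronger inhibitor of growth, a higher number a weaker inhibitor of growth), compound 1 (`COc1ccc(CN2C(=O)/C(=C\c3cc(OC)c(OC)c(OC)c3)c3ccccc32)cc1`) gives 2000 nM and compound 2 (`COc1cc(/C=C2/C(=O)N(C)c3ccc(O)cc32)cc(OC)c1OC`) gives 5700 nM as the higher of the two numbers. This gap lies beyond the scatter, so compound 2 is the weaker growth inhibitor of the pair. Compound 3 (`COc1ccc2c(c1)/C(=C\c1cc(OC)c(OC)c(OC)c1)C(=O)N2C`) has not yet been measured. Against compound 2 the change is methyl in place of hydrogen on an oxygen on an aromatic ring and reads as hydroxy to methoxy: methyl in place of hydrogen on an oxygen on an aromatic ring. Among the compounds with values here, no measured pair isolates this change, so the expectation has no direct support from the data. The expected step (a 1.9-fold lower number from compound 2 to compound 3 (0.28 log units; within the scatter)) is small and towards a lower number, and it may not clear the scatter. The estimated value for compound 3 is 3000 nM within an expected range (900 nM to 9000 nM).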

Compound 3, concentration for 50% growth inhibition: 3200 nM
Compound 3: the middle estimate sits 1.1-fold (0.03 log units) below what was measured, within the range that was stated.
By their numbers in this assay, from the lowest: compounds 1, 3 and 2 (each within the scatter of the next, the first and the last beyond it).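

In this assay, within the data shown here, the pair of compound 2 and compound 3 gives the only single-place comparison so far: hydroxy to methoxy, with methyl in place of hydrogen on an oxygen on an aromatic ring, gives a 1.8-fold lower number from compound 2 to compound 3 (0.25 log units; within the scatter). This step does not separate the two compounds, so at this position in this assay, the hydroxy and methoxy forms cannot be told apart. No measurement on hand accounts for the size of this step.

Compound 1 differs from compound 2 and from compound 3 in more than one place, so it gives no reading on this change. Still open, on these data alone, is whether a longer chain on this oxygen, such as ethoxy, or an amine in place of the hydroxy, would give a step beyond the scatter.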